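This account rests on a few compounds, and the source may have more. Where it says the series, first, only, none or still open, it means among the compounds named here.

Compound 1 `CN(C[C@H]1Cc2c(cccc2N2CCC(N)CC2)CN1)[C@H]1CCCc2cccnc21` gives 38.4%
Compound 2 `CN(C)[C@@H]1CCN(c2cccc3c2C[C@H](CN(C)[C@H]2CCCc4cccnc42)NC3)C1` gives 3.88%

In an ADME assay on microsomes from liver (Rattus norvegicus) for metabolic stability, using NADPH, with a stated time of 10 min (on this read-out lower numbers stand for a less stable compound and higher numbers for a more stable compound), compound 1 stands highest of the two measured compounds. Compound 3 `CN(C)C1CCN(c2cccc3c2C[C@H](CN(C)[C@H]2CCCc4cccnc42)NC3)CC1` differs from it by dimethylamino in place of amino on a saturated ring carbon with dimethylamino in place of amino on a saturated ring carbon. Within the data shown here, the only measured step that bears on this is a number 34.5 percentage points lower from compound 1 to compound 2 (beyond the scatter) which is large and also brings 3-(dimethylamino)pyrrolidin-1-yl in place of 4-aminopiperidin-1-yl, so the ring changes there too. A step in the same direction but of smaller size is therefore expected, namely a number 22.4 percentage points lower from compound 1 to compound 3 (beyond the scatter) in this estimate. Compound 3 is expected at 16% with an estimated range from 4% to 32% around it.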

Compound 3, percent of the compound remaining: 52.4%
The estimate for compound 3 lay 36.4 percentage points below the measured number; the measured number lies above the stated range.
By their numbers in this assay, from the lowest: compound 2; then compound 1; then compound 3.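

In this assay, dimethylamino on the saturated ring carbon does not lower the number while the six-membered ring is kept, with a number 14 percentage points higher from compound 1 to compound 3 (beyond the scatter). The steep fall seen earlier therefore follows the ring change rather than the dimethylamino group: 4-(dimethylamino)piperidin-1-yl in place of 3-(dimethylamino)pyrrolidin-1-yl gives a number 48.5 percentage points higher from compound 2 to compound 3 (beyond the scatter). Nothing available explains either step. As far as these compounds go, what a methylamino or hydroxyl group on that carbon would give stays open, as does how 3-aminopyrrolidin-1-yl would compare with 3-(dimethylamino)pyrrolidin-1-yl.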